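The source may report more compounds than this note shows. Statements on the series, on what has been measured and on what is new or still open speak of the compounds shown alone.

Of the compounds shown here, three have been tested in a functional assay on B16 cells (Mus musculus) for cytotoxicity, read by MTT assay, with a stated time of 48 h; a lower number here means a stronger inhibitor, a higher number a weaker inhibitor. Going by the values given here, compound 1 `COc1cccc(Cn2cc(-c3ccc(C)cc3)nn2)c1` is the only one with a measured number: in this assay compound 1 gives 19500 nM. Compound 2 `Cc1cccc(-c2cn(C[C@H]3COC(C)(C)O3)nn2)c1` reaches no measurable value, and in this assay compound 2 is reported only as the limit > 100000 nM. Compound 3 `CCOC(=O)Cn1cc(C(O)c2ccc3ccccc3c2)nn1` likewise is reported in this assay only as the limit > 100000 nM. Compound 2 therefore stands at the limit of > 100000 nM in this assay, at which 2 of the 3 values shown sit, so nothing more than a floor is known for it.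

Compound 4 `Cc1cccc(-c2cn(CC3COC(C)(C)O3)nn2)c1` is the next member. Its difference from compound 2 is the two compounds have the same atoms and bonds; at least one stereo element is drawn with a configuration in one of them and without one in the other: 1 of 1 stereo elements differ; a stereocentre at a saturated ring carbon is drawn S in compound 2 and without a configuration in compound 4. Among the compounds with values here, no pair of measured compounds shows a step of this kind, so there is no measured step to lean on.

The account expects no step beyond the usual scatter from compound 2 to compound 4, which means a step of a number no higher from compound 2 to compound 4 (the limit leaves the size open) at most. Compound 4 is therefore estimated at 100000 nM, with a range from 50000 nM to 200000 nM, and it is expected that this assay will again report only a limit rather than a number.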

Compound 4, half-maximal inhibitory concentration: 41700 nM
Beside the measured number, compound 4's estimate is 2.4-fold (0.38 log units) above it; measured number outside the range, below it.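

In this assay, going by these compounds alone, a change in the stereo drawing alone now goes with a shift in the read-out: the result is an at least 2.3-fold lower number from compound 2 to compound 4 (0.37 log units; beyond the scatter), a step beyond the usual scatter, and the first one between compounds that differ in one place. Compound 2 remains a limit, > 100000 nM, so the size of this step is bounded on one side only. With no atom or bond changed, the step can be traced to only one thing: the fact that one of compounds 2 and 4 is drawn with a defined configuration and the other without, at the place where they differ

The compounds shown leave open how a compound drawn R at that saturated ring carbon would read in this assay, and what the undefined drawing of compound 4 contains. They also leave open whether an amine or a carboxylic acid in place of the saturated ring would move the number at this position.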